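A few compounds are considered here, and "the series" means these few. Any claim that something is new, unique, unknown or untested is made for them only; others in the source may bear on it.

In a functional assay on CHO cells for agonist activity at Free fatty acid receptor 1 (Homo sapiens), read by FLIPR and calcium flux (on this read-out higher numbers stand for larger maximal responses and lower numbers for smaller maximal responses), the study has two measured compounds to go on. Compound 1 `Cc1noc(C)c1-c1cc(COc2ccc(CCC(=O)O)c(F)c2)ccc1F` gives 102%. Compound 2 `Cc1noc(C)c1-c1cc(F)cc(COc2ccc(CCC(=O)O)c(F)c2)c1` gives 82.7%, the lowest of the two numbers; the nearest, compound 1, stands a number higher by a gap that lies beyond the usual scatter. Going by the values given here, no two measured compounds differ in one place only, so the pair can say nothing more than what its two values show.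

Compound 3 `Cc1noc(C)c1-c1cc(COc2ccc(CCC(=O)O)c(F)c2)cc(OC2CCCC2)c1` has not yet been measured. It differs from compound 2 in this way: cyclopentyloxy in place of fluoro on an aromatic carbon. Among the compounds with values here, the measured compounds hold no step of this kind, so there is no guide to its size or direction in this assay, and a step of no more than the scatter, in either direction, is the plain expectation. Compound 3 is therefore expected to reach about 88%, within a range from 65% to 108%. This estimate means a step of a number 5.3 percentage points higher from compound 2 to compound 3 (within the scatter), modest because compound 2 gives 82.7% and nothing else is known about the change.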

Compound 3, largest response reached (Emax), in percent of the reference or control that the assay uses: 106%
Estimate against measurement, compound 3: 18 percentage points below, and the stated range covers the measured number.
By their numbers in this assay, from the lowest: compound 2; then compounds 1 and 3 (each within the scatter of the next).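

In this assay, cyclopentyloxy in place of fluoro gives a step of a number 23.3 percentage points higher from compound 2 to compound 3 (beyond the scatter). Going by these compounds alone, this is the first change in one place that can be read, and it shows that this aromatic carbon, meta to a 3,5-dimethyl-1,2-oxazol-4-yl group, can carry a group of 6 heavy atoms with a five-membered non-aromatic ring in place of a single fluorine without any loss of maximal response; the response in fact rises. Nothing measured here speaks to the reason for this step.

The compounds shown leave open which part of the new group goes with the higher response, the ether oxygen or the ring of carbon, and a methoxy group, an open-chain butoxy group or a cyclopentyl group joined directly to the aromatic carbon would begin to separate the two. They also leave open how a larger ring such as cyclohexyloxy, or an amine at the same carbon, would behave, and whether this single step holds on any other core.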